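Removing One Methyl Group from Compound 3

The source may report more compounds than this note shows. Statements on the series, on what has been measured and on what is new or still open speak of the compounds shown alone.

Of the compounds shown here, three have so far been measured in a functional assay on T47D cells (Homo sapiens) for cytotoxicity, with a stated time of 72 h, tested at 50 ug/mL; a lower number here means a weaker effect, a higher number a stronger effect of the compound at the concentration tested. Compound 1 `O=c1[nH]nc2n(c1=O)CCN2c1ccccc1` gives 0%, compound 2 `N/N=C1\NCCN1c1ccccc1Cl` gives 27%, and compound 3 `Cc1cccc(N2CCn3c2n[nH]c(=O)c3=O)c1C` gives 22%. Among these three numbers compound 3 stands second highest; its value and that of compound 2 differ by an amount within the usual scatter, so no order between the two can be claimed, whereas its gap to compound 1 lies beyond the scatter.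

Compound 4 `Cc1ccccc1N1CCn2c1n[nH]c(=O)c2=O` has not yet been measured. It differs from compound 3 in a single place: hydrogen in place of methyl on an aromatic carbon. The leaving methyl carries one heavy atom and no ring, and a hydrogen atom enters at an aromatic carbon that is ortho to a methyl group and meta to a large group.

Among the measured compounds shown here, no step between two measured compounds that differ in one place is available. Compound 1 carries no methyl on its phenyl ring and gives the lowest number, while compound 3 carries two and gives a higher one. On this footing the step from compound 3 to compound 4 is expected to be a number 10 percentage points lower from compound 3 to compound 4 (within the scatter), a decrease of a size near the edge of the scatter. Compound 4 is therefore estimated at 12%, with a range from 0% to 28%.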

Compound 4, a percentage reported as inhibition, at one concentration (the size of the read-out at that concentration, not a potency): 0%
The estimate for compound 4 lay 12 percentage points above the measured number, within the range that was stated.
By their numbers in this assay, from the lowest: compounds 1 and 4 (each within the scatter of the next); then compounds 3 and 2 (each within the scatter of the next).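

The methyl group at this place carries the whole signal in this series: in this assay, its loss gives a number 22 percentage points lower from compound 3 to compound 4 (beyond the scatter). The opposite change on the shared core, methyl in place of hydrogen on an aromatic carbon, gives no change at the digits printed from compound 1 to compound 4 (within the scatter), so a single methyl group on the ring, at the place it holds in compound 4, adds nothing measurable, and only compound 3, with two, stands clear of the scatter. No measurement at hand explains why the second methyl group matters.

Among the compounds shown here, it remains open whether methyl is the only group that works at this place, or whether an ethyl group, a methoxy group or a chlorine atom would also hold the read-out. For the compounds shown here, also unresolved is whether a methyl group here would give a read-out on its own, without the one that compound 4 retains.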